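Swapping the aromatic group on a shared terpenoid core

The compounds below may be only part of what the source reports. "The series", "measured", "known", "first", "only" and "open" are said of these compounds alone.

Three compounds sharing one core have been measured in an ADME assay on L132 cells (Homo sapiens) for cytotoxicity, read by MTT assay, with a stated time of 48 h; a higher number here means a weaker inhibitor, a lower number a stronger inhibitor:

Compound 1 `C/C(=C\CC/C(C)=C/CC[C@@H]1[C@@]2(C)CCC(=O)C(C)(C)[C@H]2CC[C@@]1(C)O)CC/C=C(\C)C(=O)OCc1cn(-c2ccc(C(F)(F)F)cc2)nn1` gives > 150000 nM, which is a limit of the assay and not a number.
Compound 2 `C/C(=C\CC/C(C)=C/CC[C@@H]1[C@@]2(C)CCC(=O)C(C)(C)[C@H]2CC[C@@]1(C)O)CC/C=C(\C)C(=O)OCc1cn(-c2cccc(Cl)c2)nn1` gives 94200 nM.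
Compound 3 `C/C(=C\CC/C(C)=C/CC[C@@H]1[C@@]2(C)CCC(=O)C(C)(C)[C@H]2CC[C@@]1(C)O)CC/C=C(\C)C(=O)OCc1cn(-c2ccccc2F)nn1` gives > 150000 nM, again a limit of the assay.

Compound 1 therefore stands at the limit, and only compound 2 supplies a number. The measured steps are an at least 1.5-fold lower number from compound 1 to compound 2 (0.20 log units; that floor lies within the scatter) and an at least 1.5-fold higher number from compound 2 to compound 3 (0.20 log units; that floor lies within the scatter), while a step that the two limits leave unreadable from compound 1 to compound 3; all of this sits close to the scatter, and (the limit of > 150000 nM in this assay, at which 2 of the 3 values shown sit).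

Compound 4 `C/C(=C\CC/C(C)=C/CC[C@@H]1[C@@]2(C)CCC(=O)C(C)(C)[C@H]2CC[C@@]1(C)O)CC/C=C(\C)C(=O)OCc1cn(-c2cccc(C)c2)nn1` is the unmeasured partner. It differs from compound 1 as follows: 3-methylphenyl in place of 4-(trifluoromethyl)phenyl on an aromatic nitrogen. Within the data shown here, the only step that bears on it is an at least 1.5-fold lower number from compound 1 to compound 2 (0.20 log units; that floor lies within the scatter), where a halogenated phenyl replaced the same 4-(trifluoromethyl)phenyl and the number dropped only slightly. Compound 4, bearing 3-methylphenyl, is expected to behave alike, with a step of an at least 1.3-fold lower number from compound 1 to compound 4 (0.13 log units; that floor lies within the scatter) that may not clear the scatter. The estimate for compound 4 is 110000 nM, in a range from 50000 nM to 200000 nM.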

Compound 4, half-maximal inhibitory concentration: > 150000 nM
Compound 4: a limit, no number (the forecaster's own chance of this, stated with the estimate: 50%); middle value at least 1.3-fold (0.13 log units) away from the limit.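

Compound 4, with 3-methylphenyl on the aromatic nitrogen, also gives a limit of the assay and not a number, which extends the limit to a third aromatic group: the limit of > 150000 nM in this assay, at which 3 of the 4 values shown sit. Methyl in place of chloro gives an at least 1.5-fold higher number from compound 2 to compound 4 (0.20 log units; that floor lies within the scatter), so even the one compound with a number is not shown to stand clearly apart from compound 4. The steps from compound 1 and from compound 3 to compound 4 join limit to limit and cannot be read.

Going by these compounds, what a phenyl ring carrying an amine or a carboxylic acid would give in this assay remains open. Also open, on these data alone, is whether any group on this aromatic nitrogen can bring the shared core to a number clearly beyond the scatter.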